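Swapping fluoro for acetamido in compound 4

The compounds below may be only part of what the source reports. "The series", "measured", "known", "first", "only" and "open" are said of these compounds alone.

Measured so far in a functional assay on HepG2 cells (Homo sapiens) for cytotoxicity, read by MTT assay, with a stated time of 24 h; a lower number here means a stronger inhibitor, a higher number a weaker inhibitor:

Compound 1 `O=C1/C(=C/c2cccc([N+](=O)[O-])c2)CN(S(=O)(=O)c2ccc(F)cc2)C/C1=C\c1cccc([N+](=O)[O-])c1` gives 8760 nM
Compound 2 `COc1cc(/C=C2\CN(S(=O)(=O)c3ccc(NC(C)=O)cc3)C/C(=C\c3cc(OC)c(OC)c(OC)c3)C2=O)cc(OC)c1OC` gives 3890 nM
Compound 3 `COc1cc(/C=C2\CN(S(=O)(=O)c3ccc(F)cc3)C/C(=C\c3cccc([N+](=O)[O-])c3)C2=O)cc(OC)c1OC` gives 3250 nM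

Compound 3 at 3250 nM stands level with compound 2 at 3890 nM within the scatter. The remaining gap is a 2.7-fold lower number from compound 1 to compound 3 (0.43 log units; beyond the scatter) and comes with a trimethoxyphenyl group in place of a nitrophenyl group.

Compound 4 `COc1cc(/C=C2\CN(S(=O)(=O)c3ccc(NC(C)=O)cc3)C/C(=C\c3cccc([N+](=O)[O-])c3)C2=O)cc(OC)c1OC` differs from compound 3 in one place, with acetamido in place of fluoro on an aromatic carbon, para to a large group, and acetamido in place of fluoro on an aromatic carbon as the count of that change. Within the data shown here, no measured step makes this swap directly. Among the measured compounds shown here, compound 2 is the only measured compound with acetamido, and it gives 3890 nM with two trimethoxyphenyl groups. Compound 4 has a nitrophenyl group in place of one of these. For the measured compounds named here, the only measured step on that swap, a 2.7-fold lower number from compound 1 to compound 3 (0.43 log units; beyond the scatter) when read backwards, points to a higher number.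

A modest rise is therefore expected in this assay, although this rests on a single step on a different background. The expected change is a 2.0-fold higher number from compound 3 to compound 4 (0.30 log units; within the scatter) and it may prove smaller. For compound 4 the estimated value is 6500 nM with an expected range from 3000 nM to 13000 nM and no more certainty than that.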

Compound 4, half-maximal inhibitory concentration: 3340 nM
Beside the measured number, compound 4's estimate is 1.9-fold (0.29 log units) above it; the range from low to high includes it.
By their numbers in this assay, from the lowest: compounds 3, 4 and 2 (each within the scatter of the next); then compound 1.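

In this assay, the change from 4-fluorophenyl to 4-acetamidophenyl can now be read directly, as a 1.0-fold higher number from compound 3 to compound 4 (0.01 log units; within the scatter), so on this background the larger acetamido group at this position, para to a large group, leaves no change that stands out from the scatter. The second new step, a 1.2-fold lower number from compound 2 to compound 4 (0.07 log units; within the scatter), shows that once acetamido is present, exchanging one 3,4,5-trimethoxyphenyl group for 3-nitrophenyl also stays within the scatter. The gain seen earlier with 3,4,5-trimethoxyphenyl in place of 3-nitrophenyl therefore does not carry over from one core to the other: the same change on two cores in this assay, a 2.7-fold lower number (0.43 log units; beyond the scatter) from compound 1 to compound 3 and a 1.2-fold higher number (0.07 log units; within the scatter) from compound 4 to compound 2, 3.1-fold (0.50 log units) apart, beyond the scatter of two such steps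

The compounds shown leave open whether an amine or a carboxylic acid at this position would also stay level with fluoro and acetamido, the only two groups seen there. Among these compounds, they also do not tell whether the swap from fluoro to acetamido would read the same with two 3-nitrophenyl groups or two 3,4,5-trimethoxyphenyl groups, as the one direct pair carries one of each.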